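This account rests on a few compounds, and the source may have more. Where it says the series, first, only, none or still open, it means among the compounds named here.

Measured so far: compound 1 `Oc1nc(NCC2CCCCC2)nc2ccc(Cl)cc12` gives 86% in a functional assay on the whole organism (uterus) with Rattus norvegicus as the target, tested at 10 uM; on this read-out higher numbers stand for a weaker effect at the one concentration tested and lower numbers for a stronger effect; compound 2 `C[C@@H](Nc1nc(O)c2cc(Cl)ccc2n1)C1CCCCC1` gives 108%; compound 3 `Oc1nc(NCc2ccccc2)nc2ccc(Cl)cc12` gives 94.8%.

Compound 3 sits second highest of the three; its nearest neighbour is compound 1, within the scatter, and its furthest is compound 2, beyond the scatter. Compound 4 `C[C@@H](Nc1nc(O)c2cc(Cl)ccc2n1)c1ccccc1` differs from compound 3 by methyl in place of hydrogen on a saturated chain carbon bound to an aromatic carbon and a nitrogen on an aromatic ring. The step that bears on this is the same methyl introduction on the cyclohexyl partner, a number 22 percentage points higher from compound 1 to compound 2 (beyond the scatter), a modest rise. The swap of phenyl for cyclohexyl, a number 8.8 percentage points higher from compound 1 to compound 3 (within the scatter), stayed within the scatter, so the methyl effect is expected to carry over. Compound 4 is therefore expected to give a weaker effect, estimated at 112% (range 97% to 127%), a step of a number 17.2 percentage points higher from compound 3 to compound 4 (beyond the scatter).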

Compound 4, a percentage reported as activity, at one concentration (the size of the read-out at that concentration, not a potency): 120%
Estimate against measurement, compound 4: 8 percentage points below; measured number inside the range.
By their numbers in this assay, from the lowest: compounds 1 and 3 (each within the scatter of the next); then compound 2; then compound 4.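

With methyl in place of hydrogen on this saturated chain carbon, the step is a number 25.2 percentage points higher from compound 3 to compound 4 (beyond the scatter) and the effect is thus weakened with a phenyl partner as it was with a cyclohexyl partner: the same change on two cores in this assay, a number 22 percentage points higher (beyond the scatter) from compound 1 to compound 2 and a number 25.2 percentage points higher (beyond the scatter) from compound 3 to compound 4, 3.2 percentage points apart, within the scatter of two such steps. Phenyl in place of cyclohexyl gives a number 12 percentage points higher from compound 2 to compound 4 (beyond the scatter) and shifts the number similarly with or without the methyl: the same change on two cores in this assay, a number 8.8 percentage points higher (within the scatter) from compound 1 to compound 3 and a number 12 percentage points higher (beyond the scatter) from compound 2 to compound 4, 3.2 percentage points apart, within the scatter of two such steps. Across these four compounds, the two changes appear to add up.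

The compounds shown leave open whether a longer chain such as ethyl, or an amine, on this carbon would weaken the effect further.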